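Amine swap on a weakly antiproliferative series

The source may report more compounds than this note shows. Statements on the series, on what has been measured and on what is new or still open speak of the compounds shown alone.

Measured in a functional assay on FM3A cells (Mus musculus) for antiproliferative activity, read by cell counting, with a stated time of 2 days; a higher number here means a weaker inhibitor, a lower number a stronger inhibitor:
- compound 1 `CCN(CC)c1nc(N)c(C(=O)c2cc(OC)c(OC)c(OC)c2)s1`: 115000 nM
- compound 2 `COc1cc(C(=O)c2sc(N(C)Cc3ccccc3)nc2N)cc(OC)c1OC`: > 200000 nM

Compound 2 stands at > 200000 nM, which is a limit and not a number. Compound 3 `COc1cc(C(=O)c2sc(N3CCCC3)nc2N)cc(OC)c1OC` carries pyrrolidin-1-yl in place of benzyl(methyl)amino on an aromatic carbon. For the measured compounds named here, the one measured step bearing on this is an at least 1.7-fold higher number from compound 1 to compound 2 (0.24 log units; that floor lies within the scatter). Going by the values given here, a small step towards a lower number is expected in this assay, within the scatter, with compound 1 at 115000 nM as the only measured number. Compound 3 is estimated at 100000 nM, with a range of 30000 nM to 200000 nM. The expected step is an at least 2.0-fold lower number from compound 2 to compound 3 (0.30 log units; that floor lies within the scatter).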

Compound 3, half-maximal inhibitory concentration: 180 nM
Compound 3: middle estimate off by 560-fold (2.74 log units), on the high side; measured number outside the range, below it.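

In this assay, the group on this aromatic carbon, next to the ring nitrogen and next to the ring sulfur, sets the level of activity: pyrrolidin-1-yl gives an at least 1100-fold lower number from compound 2 to compound 3 (3.04 log units; beyond the scatter) and a 640-fold lower number from compound 1 to compound 3 (2.81 log units; beyond the scatter). Diethylamino and benzyl(methyl)amino had shown only weak compounds, so the earlier pair gave no sign that this position could reach such a level. Compound 2 carries a limit and not a number, so the first step is a floor: the limit of > 200000 nM in this assay, at which 1 of the 3 values shown sits.

As far as these compounds go, it stays open whether piperidin-1-yl or morpholin-4-yl holds this level. The same applies to dimethylamino, an open-chain amine.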